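The source may hold more compounds than are shown below. What is called first, only, known or untested is meant among the compounds shown, and "the series" means these compounds.

Measured so far in a physicochemical assay for solubility, using the shake flask method, measured as kinetic solubility, with a stated time of 20 h, at pH 2; on this read-out lower numbers stand for lower solubility and higher numbers for higher solubility:
Compound 1 `Fc1ccc(Nc2cc3[nH]c(-c4cccc(C(F)(F)F)c4)nc3cn2)nc1`: < 5000 nM
Compound 2 `FC(F)(F)c1ccc(Nc2cc3[nH]c(-c4cccc(C(F)(F)F)c4)nc3cn2)nc1`: < 5000 nM
Compound 3 `O=C(O)c1ccc(Nc2cc3[nH]c(-c4cccc(C(F)(F)F)c4)nc3cn2)nc1`: < 5000 nM

Compound 2 is known only by the limit < 5000 nM and not by a number. The whole set offers the limit of < 5000 nM in this assay, at which 3 of the 3 values shown sit, and nothing sharper. In compound 4 `FC(F)(F)c1ccc(Nc2cc3[nH]c(CC4CC4)nc3cn2)nc1` cyclopropylmethyl stands in place of 3-(trifluoromethyl)phenyl (cyclopropylmethyl in place of 3-(trifluoromethyl)phenyl on an aromatic carbon). The measured steps are a step that the two limits leave unreadable from compound 1 to compound 2 and a step that the two limits leave unreadable from compound 1 to compound 3 and a step that the two limits leave unreadable from compound 2 to compound 3 and all three change a different group, so they offer no size to carry over. The expectation therefore rests on the structural change alone and stays loose. The expected step is an at least 4.0-fold higher number from compound 2 to compound 4 (0.60 log units; beyond the scatter) in this assay and it is expected to point toward higher numbers. For compound 4 the estimate is 20000 nM with an expected range from 3000 nM to 100000 nM for the measurement.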

Compound 4, solubility: 186000 nM
Estimate against measurement, compound 4: 9.3-fold (0.97 log units) below, and the stated range ends below it.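

In this assay, among the compounds shown here, the position between two ring nitrogen atoms gives the first readable step in this set: cyclopropylmethyl in place of 3-(trifluoromethyl)phenyl produces an at least 37-fold higher number from compound 2 to compound 4 (1.57 log units; beyond the scatter). From the compounds shown here alone, compound 2 is known only as a limit, so the full size of this step stays unknown. The steps among compound 1, compound 2 and compound 3 cannot be read, since each compound gives only a limit: the limit of < 5000 nM in this assay, at which 3 of the 4 values shown sit.

The compounds shown leave open whether the ring or its trifluoromethyl matters more. A plain phenyl, an amine or a longer alkyl chain at this position could help separate the two.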